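The source may report more compounds than this note shows. Statements on the series, on what has been measured and on what is new or still open speak of the compounds shown alone.

Three thiosemicarbazones were tested in an ADME assay on Vero cells (Chlorocebus sabaeus) for cytotoxicity, read by MTT assay, with a stated time of 72 h; a lower number here means that less compound is tolerated, a higher number that more compound is tolerated. Compound 1 `C=CCN(CC=C)C(=S)N/N=C(/C)c1ccc(F)cc1` gives 214000 nM, the largest of the three numbers, yet the gaps to the other two lie within the usual scatter. For the measured compounds named here, compound 2 `C=CCN(CC=C)C(=S)N/N=C\c1ccc(Cl)cc1` gives 213000 nM, and compound 3 `C/C(=N/NC(=S)N(Cc1ccccc1)Cc1ccccc1)c1ccc(F)cc1` gives 160000 nM, so no compound can be called more or less tolerated than another on these data. Compound 4 `C=CCN(CC=C)C(=S)N/N=C(/C)c1ccc([N+](=O)[O-])cc1` has not yet been tested. It differs from compound 1 by nitro in place of fluoro on an aromatic carbon. Going by the values given here, no measured pair shows what such a change does here, and the three measured values sit close together, so compound 4 is expected to stay near compound 1, with a step of a 1.2-fold lower number from compound 1 to compound 4 (0.08 log units; within the scatter) that should not exceed the scatter. Compound 4 is therefore estimated at 180000 nM, within a range of 90000 nM to 360000 nM.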

Compound 4, half-maximal cytotoxic concentration: < 197000 nM
Compound 4: a limit, no number (the forecaster's own chance of this, stated with the estimate: 10%); the middle value is on the limit's open side.
By their numbers in this assay, from the lowest: compounds 3, 2 and 1 (each within the scatter of the next).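

In this assay compound 4 gives < 197000 nM, which is a limit of the assay and not a number: the limit of < 197000 nM in this assay, at which 1 of the 4 values shown sits. Nitro in place of fluoro on this aromatic carbon gives an at least 1.0-fold lower number from compound 1 to compound 4 (0.03 log units; that floor lies within the scatter), the first step in the set that can be read at a single position. That step is only a floor, so the true size of the change could be larger.

As far as these compounds go, the actual number for compound 4 stays open. So does what an amine or a carboxylic acid on this aromatic carbon would do.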